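The source may report more compounds than this note shows. Statements on the series, on what has been measured and on what is new or still open speak of the compounds shown alone.

Measured so far in a functional assay on CCRF-CEM cells for antagonist activity at C-X-C chemokine receptor type 4 (Homo sapiens), read by calcium flux, with stated times of 25 min and 90 s; on this read-out higher numbers stand for weaker inhibition and lower numbers for stronger inhibition:

- compound 1, `c1ccc2c(c1)CN[C@@H](CN(CC1CCNCC1)[C@H]1CCCc3cccnc31)C2`: 65 nM
- compound 2, `c1cnc2c(c1)CN[C@H](CN(CCCN1CCNCC1)[C@H]1CCCc3cccnc31)C2`: 2640 nM

Within the data shown here, compound 1 holds the lower of the two numbers in this assay, and compound 2, which differs from it in more than one place, comes in much higher; with no single-step pair between them, the two values show only that the pair spans a wide gap, well beyond the scatter.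

Compound 3, `c1ccc2c(c1)CN[C@@H](CN(CCCN1CCN(C3CC3)CC1)[C@H]1CCCc3cccnc31)C2`, has not yet been run in this assay. It keeps the core of compound 1 and changes only the side chain on the amine nitrogen: a group of 11 heavy atoms (9 carbon, 2 nitrogen; one three-membered non-aromatic ring of carbon only, one six-membered non-aromatic ring with 2 hetero atoms) in place of a group of 6 heavy atoms (5 carbon, 1 nitrogen; one six-membered non-aromatic ring with 1 hetero atom), on a saturated chain carbon bound to an amine nitrogen. The piperazine-propyl chain of compound 3 resembles the chain of compound 2, but compound 2 also carries a different core and an unsubstituted piperazine, so its value cannot be read as a guide for this single change.

Among the measured compounds shown here, with only two measured compounds and no single-step pair among them, the expectation for compound 3 rests on the size of the change alone: a step of moderate size toward weaker inhibition is expected, a 2.3-fold higher number from compound 1 to compound 3 (0.36 log units; beyond the scatter), though a result within the scatter of compound 1 would not surprise. Compound 3 is estimated at 150 nM, with a likely range from 40 nM to 600 nM.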

Compound 3, half-maximal inhibitory concentration: 50 nM
The estimate for compound 3 lay 3.0-fold (0.48 log units) above the measured number; low and high end bracket the measured number.
By their numbers in this assay, from the lowest: compounds 3 and 1 (each within the scatter of the next); then compound 2.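

In this assay, the side chain on the amine nitrogen accepts a much larger group than piperidin-4-yl without a change beyond the scatter: a 1.3-fold lower number from compound 1 to compound 3 (0.11 log units; within the scatter). Among these compounds, the single step therefore shows that, on a saturated chain carbon bound to an amine nitrogen, a group of 11 heavy atoms with two rings can stand in place of one of 6 heavy atoms with one ring, and that going from 1 hydrogen-bond donor to 0 hydrogen-bond donors in this group leaves the number within the scatter on the core of compound 1. No measurement is at hand that accounts for this result.

Still open, as far as these compounds go, is what the three-membered ring contributes to this value, which a methyl or acetyl group in its place would test on the same core. Among the compounds shown here, also open is how much the length of the chain matters, since a two-carbon or four-carbon chain leading to the same piperazine would show whether this reading holds beyond the one group.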